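Trimming Isopropyl to Ethyl on a Weakly Active Compound

This account rests on a few compounds, and the source may have more. Where it says the series, first, only, none or still open, it means among the compounds named here.

For the measured compounds named here, compound 2 `CC(C)n1c(/C=C2/C(=O)Nc3ccc(Cl)cc32)nc2ccccc21` holds the only number in this small set: in a functional assay on MCF7 cells (Homo sapiens) for cytotoxicity, read by MTT assay, with a stated time of 48 h (on this read-out higher numbers stand for weaker inhibition and lower numbers for stronger inhibition), compound 2 gives 24000 nM as its result. Compound 1 `CCn1c(/C=C2/C(=O)Nc3ccc(Br)cc32)nc2ccccc21` offers no second point of comparison, for in this assay compound 1 stands as "not determined" (no result reported) with no figure behind it.

Compound 3 `CCn1c(/C=C2/C(=O)Nc3ccc(Cl)cc32)nc2ccccc21` has yet to be measured. It departs from compound 2 in one place, isopropyl to ethyl (hydrogen in place of methyl on a saturated chain carbon bound to an aromatic nitrogen and a saturated chain carbon), that is, hydrogen in place of methyl on a saturated chain carbon bound to an aromatic nitrogen and a saturated chain carbon.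

Going by the values given here, no pair of measured compounds shows how far this assay moves for a change of this kind, so the expectation is a step no bigger than the usual scatter, with neither direction favoured. That expectation leans on compound 2 and its 24000 nM alone. The estimated change a 1.1-fold lower number from compound 2 to compound 3 (0.04 log units; within the scatter) is accordingly small. For compound 3 the estimate is 22000 nM with an expected range of 9000 nM to 50000 nM in this assay once measured.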

Compound 3, half-maximal inhibitory concentration: > 50000 nM
Compound 3: only a limit was reported (the forecaster's own chance of this, stated with the estimate: 10%); middle value at least 2.2-fold (0.35 log units) from the limit.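

Compound 3 carries a limit of the assay, not a number: in this assay compound 3 gives > 50000 nM. Even so, trimming isopropyl to ethyl gives the first readable step in this set, an at least 2.0-fold higher number from compound 2 to compound 3 (0.31 log units; beyond the scatter), so at this place, on a saturated chain carbon bound to an aromatic nitrogen and a saturated chain carbon, the loss of one methyl takes an already weak result further towards weaker inhibition instead of leaving it within the scatter. The true size of the step stays unknown because one end of it is not a number: the limit of > 50000 nM in this assay, at which 1 of the 3 values shown sits.

For the compounds shown here, with only two compounds on this step, the result shows that isopropyl outdoes ethyl here, but not whether a larger group in the same place, such as a butyl chain or a benzyl group, would bring stronger inhibition. On these data alone, the step between the bromo compound 1 and the chloro compound 3 cannot be read, so the effect of the halogen on the shared core also remains open.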